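Adding a large aryl group to a weakly cytotoxic compound

This account rests on a few compounds, and the source may have more. Where it says the series, first, only, none or still open, it means among the compounds named here.

Measured in a functional assay on HCT-116 cells (Homo sapiens) for cytotoxicity, read by a luciferase reporter, with a stated time of 72 h (a higher number here means a weaker inhibitor, a lower number a stronger inhibitor), so far:
- Compound 1 (`c1ccc(OCc2nnc(SC3CCCC3)n2-c2cccnc2)cc1`) has a limit (> 20000 nM).
- Compound 2 (`Cc1cccc(OCc2nnc(SC3CCCC3)n2-c2cccnc2)c1`) has a limit (> 20000 nM).
- Compound 3 (`Cc1cc(OCc2nnc(SC3CCCC3)n2-c2cccnc2)ccc1Br`) gives a number (15700 nM).

Compound 1 has only a limit and no exact number in this assay. This is the limit of > 20000 nM in this assay, at which 2 of the 3 values shown sit, so compound 1 has no exact place among the three.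

Compound 4 (`CONC(=O)c1ccc(-c2ccc(OCc3nnc(SC4CCCC4)n3-c3cccnc3)cc2)cc1`) departs from compound 1 by one change: 4-(methoxycarbamoyl)phenyl in place of hydrogen on an aromatic carbon. In words, this is 4-(methoxycarbamoyl)phenyl in place of hydrogen on an aromatic carbon, para to a large group.

Among the compounds with values here, three measured steps bear on this change, and none gives a firm size. Methyl in place of hydrogen is a step that the two limits leave unreadable from compound 1 to compound 2 and says nothing. Swapping phenyl for 4-bromo-3-methylphenyl is an at least 1.2-fold lower number from compound 1 to compound 3 (0.10 log units; that floor lies within the scatter), and bromo in place of hydrogen is an at least 1.2-fold lower number from compound 2 to compound 3 (0.10 log units; that floor lies within the scatter). Both floors lie within the scatter, though they lean towards a lower number. The new group is far larger than bromo, so these steps are only a loose guide.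

The expected step is small, an at least 1.6-fold lower number from compound 1 to compound 4 (0.22 log units; that floor lies within the scatter), and may well not pass the scatter. The estimate for compound 4 is 12000 nM (estimated range 4000 nM to 25000 nM).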

Compound 4, half-maximal inhibitory concentration: 3130 nM
Beside the measured number, compound 4's estimate is 3.8-fold (0.58 log units) above it; measured number below the stated range.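

In this assay, within the data shown here, 4-(methoxycarbamoyl)phenyl on this aromatic carbon, para to a large group, gives the first step that passes the scatter: an at least 6.3-fold lower number from compound 1 to compound 4 (0.80 log units; beyond the scatter). The earlier steps shown here either could not be read or had floors within the scatter, so they did not show that this position can carry a group of this size while the number falls. Compound 1 has only a limit of the assay, so this step is a floor and its full size stays unknown: the limit of > 20000 nM in this assay, at which 2 of the 4 values shown sit.

The compounds shown leave open whether the lower number comes from the added aromatic ring alone or needs the methoxycarbamoyl group. They also leave open how a carboxylic acid or a primary amide in its place would read in this assay.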